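From a Branched Chain to a Small Ring on the Ester

The source may hold more compounds than are shown below. What is called first, only, known or untested is meant among the compounds shown, and "the series" means these compounds.

Measured in an assay on membranes from HEK293 cells for displacement of a labelled ligand from adenosine receptor A2b (Homo sapiens), read by scintillation counting, with a stated time of 30 min; on this read-out lower numbers stand for stronger inhibition and higher numbers for weaker inhibition:
compound 1 `CC1=C(C(=O)CC(C)C)C(c2ccoc2)NC(=O)N1` gives 1010 nM
compound 2 `CC1=C(C(=O)OCC2CC2)C(c2ccco2)NC(=O)N1` gives 138 nM
compound 3 `CCC(C)OC(=O)C1=C(C)NC(=O)NC1c1ccoc1` gives 201 nM

Compound 3 stands second highest of these three numbers: compound 2 sits a little lower, within the scatter, while the step of a 5.0-fold lower number from compound 1 to compound 3 (0.70 log units; beyond the scatter) lies beyond it. Compound 4 `CC1=C(C(=O)OCC2CC2)C(c2ccoc2)NC(=O)N1` differs from compound 3 by cyclopropylmethyl in place of sec-butyl on an oxygen next to a carbonyl group. Going by the values given here, no measured step matches this change; the only step on record also concerns the carbonyl substituent, but swaps isobutyl for sec-butoxy and is modest. Compound 2, though it differs from compound 3 in a second place as well, carries the cyclopropylmethyl ester; compound 2 gives 138 nM. Little change is therefore expected, a 1.3-fold lower number from compound 3 to compound 4 (0.10 log units; within the scatter). Compound 4 is estimated at 160 nM, from 60 nM to 400 nM.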

Compound 4, inhibition constant: 426 nM
Beside the measured number, compound 4's estimate is 2.7-fold (0.43 log units) below it, outside the stated range (above it).
By their numbers in this assay, from the lowest: compounds 2 and 3 (each within the scatter of the next); then compound 4; then compound 1.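

Cyclopropylmethyl in place of sec-butyl on this ester oxygen is not a neutral swap, even with the same count of heavy atoms: in this assay it gives a 2.1-fold higher number from compound 3 to compound 4 (0.33 log units; beyond the scatter). With the cyclopropylmethyl ester held fixed, furan-3-yl in place of furan-2-yl gives a 3.1-fold higher number from compound 2 to compound 4 (0.49 log units; beyond the scatter), while cyclopropylmethoxy in place of isobutyl still gives a 2.4-fold lower number from compound 1 to compound 4 (0.37 log units; beyond the scatter). No measured evidence here explains these shifts. Going by these compounds, whether a benzyl group on this oxygen, or a carboxylic acid in place of the ester, would give a lower or higher number remains open.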